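Replacing methoxy with methyl in compound 3

This account rests on a few compounds, and the source may have more. Where it says the series, first, only, none or still open, it means among the compounds named here.

compound 1 `CCN(CC)CN1C(=O)/C(=N/NC(=S)Nc2ccccc2)c2cc(Cl)ccc21` gives 40000 nM
compound 2 `CCN(CC)CN1C(=O)/C(=N/NC(N)=S)c2cc(Cl)ccc21` gives 71000 nM
compound 3 `CCN(CC)CN1C(=O)/C(=N/NC(=S)Nc2ccc(OC)cc2)c2cc(Cl)ccc21` gives 6900 nM

These values come from a functional assay on CCRF-CEM cells (Homo sapiens) for inhibition, read by cell counting, with a stated time of 72 h (a lower number here means a stronger inhibitor, a higher number a weaker inhibitor), and compound 3 has the lowest number of the three. Compound 4 `CCN(CC)CN1C(=O)/C(=N/NC(=S)Nc2ccc(C)cc2)c2cc(Cl)ccc21` differs from it by methyl in place of methoxy on an aromatic carbon, para to a large group (methyl in place of methoxy on an aromatic carbon). The closest measured step is a 5.8-fold lower number from compound 1 to compound 3 (0.76 log units; beyond the scatter), where methoxy replaces hydrogen at that same place. Also relevant is a 10-fold lower number from compound 2 to compound 3 (1.01 log units; beyond the scatter), whereas a 1.8-fold higher number from compound 1 to compound 2 (0.25 log units; within the scatter) stays within the scatter. No methyl at this place has been measured, so methyl is expected to keep only part of the gain seen in the step to compound 3. This reasoning points to an expected modest rise in the number, an estimated 1.9-fold higher number from compound 3 to compound 4 (0.28 log units; within the scatter). The estimate for compound 4 is 13000 nM, with an expected range from 5000 nM to 35000 nM.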

Compound 4, half-maximal inhibitory concentration: 4600 nM
For compound 4 the middle estimate is 2.8-fold (0.45 log units) above the measured one, outside the stated range (below it).
By their numbers in this assay, from the lowest: compounds 4 and 3 (each within the scatter of the next); then compounds 1 and 2 (each within the scatter of the next).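

In this assay, methyl in place of methoxy on this aromatic carbon gives a 1.5-fold lower number from compound 3 to compound 4 (0.18 log units; within the scatter) and so leaves the number within the scatter, which shows that the oxygen of methoxy is not needed here. Methyl also keeps the gain over the unsubstituted phenyl, with an 8.7-fold lower number from compound 1 to compound 4 (0.94 log units; beyond the scatter) and, against the plain thiosemicarbazone, a 15-fold lower number from compound 2 to compound 4 (1.19 log units; beyond the scatter) as the larger step. Nothing measured here explains why these two groups match. Going by these compounds, whether an amine, a carboxylic acid, chlorine or a longer chain such as ethoxy would fit this place stays open.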